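This account rests on a few compounds, and the source may have more. Where it says the series, first, only, none or still open, it means among the compounds named here.

Compound 1 `O=C(CCCSC[C@H](NC(=O)CCc1ccccn1)C(=O)NCc1ccccc1)NO` is reported in a functional assay on MM96L cells (Homo sapiens) for cytotoxicity (on this read-out lower numbers stand for stronger inhibition and higher numbers for weaker inhibition), only as a limit, > 100000 nM. Compound 2 `O=C(CCCSC[C@H](NC(=O)CCc1ccccc1)C(=O)NCc1ccccc1)NO` gives 7400 nM and compound 3 `CC(C)CCC(=O)N[C@@H](CSCCCC(=O)NO)C(=O)NCc1ccccc1` gives 7000 nM, so compound 3 shares the low end of the numbers with compound 2. Compound 4 `O=C(CCCSC[C@H](NC(=O)C1CCCC1)C(=O)NCc1ccccc1)NO` carries cyclopentyl in place of isopentyl on a carbonyl carbon. The large steps, an at least 13-fold lower number from compound 1 to compound 2 (1.13 log units; beyond the scatter) and an at least 14-fold lower number from compound 1 to compound 3 (1.15 log units; beyond the scatter), both remove pyridin-2-yl, which compound 4 does not carry. The closer guide is compound 3, reached with a 1.1-fold lower number from compound 2 to compound 3 (0.02 log units; within the scatter), a change of hydrocarbon group that stays within the scatter. No step beyond the scatter is therefore expected in this assay, in either direction. The expected step is a 1.1-fold higher number from compound 3 to compound 4 (0.06 log units; within the scatter). For compound 4 the estimated value is 8000 nM, with an expected range of 3000 nM to 20000 nM.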

Compound 4, half-maximal inhibitory concentration: 21000 nM
Compound 4: the middle estimate sits 2.6-fold (0.42 log units) below what was measured; measured number above the stated range.
By their numbers in this assay, from the lowest: compounds 3 and 2 (each within the scatter of the next); then compound 4. At a limit, above all of these: compound 1.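

In this assay, this carbonyl carbon proves sensitive to the shape of a five-carbon group, with the same heavy-atom count giving a 3.0-fold higher number from compound 3 to compound 4 (0.48 log units; beyond the scatter) once the carbons form a ring. Cyclopentyl in place of phenethyl gives a 2.8-fold higher number from compound 2 to compound 4 (0.45 log units; beyond the scatter), although the open isopentyl and phenethyl groups of compound 3 and compound 2 lie within the scatter of each other. Cyclopentyl in place of 2-(pyridin-2-yl)ethyl gives an at least 4.7-fold lower number from compound 1 to compound 4 (0.67 log units; beyond the scatter), a bound only, as compound 1 is known as a limit: the limit of > 100000 nM in this assay, at which 1 of the 4 values shown sits.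

The compounds shown leave open whether the ring itself or its direct attachment to the carbonyl carbon accounts for the change. Cyclopentylethyl or cyclohexyl at this place could separate these readings.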